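A few compounds are considered here, and "the series" means these few. Any claim that something is new, unique, unknown or untested is made for them only; others in the source may bear on it.

Compound 1 `O=[N+]([O-])c1ccc(Sc2ccc(NC(=S)Oc3ccc(O)cc3)cc2)cc1` and compound 2 `CC(=O)Nc1ccc(OC(=S)Nc2ccc(Sc3ccc([N+](=O)[O-])cc3)cc2)cc1` share one core and differ in a single place. In a physicochemical assay for acid dissociation, compound 1 gives 9.21, while compound 2 gives 8.99. The change between them, (acetamido in place of hydroxy on an aromatic carbon), produced a step of a number 0.22 log units lower from compound 1 to compound 2 (within the scatter).

Compound 3 `Oc1ccc(OC(=S)Nc2ccc(Nc3ccc(C(Cl)(Cl)Cl)cc3)cc2)cc1` belongs to a second series; the difference between its core and the core of compound 1 is not broken down here. In this assay compound 3 gives 9.23, a number within the scatter of compound 1 and of compound 2.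

Compound 4 `CC(=O)Nc1ccc(OC(=S)Nc2ccc(Nc3ccc(C(Cl)(Cl)Cl)cc3)cc2)cc1` is the counterpart of compound 3 in that series. It differs from compound 3 by acetamido in place of hydroxy on an aromatic carbon, and the surroundings of the place are described in the same words as for the change from compound 1 to compound 2, so this is the same change made on a second core.

On that basis compound 4 is expected to sit close to compound 3, with an estimated step of a number 0.22 log units lower from compound 3 to compound 4 (within the scatter), because the earlier step of a number 0.22 log units lower from compound 1 to compound 2 (within the scatter) was small. The estimate for compound 4 in this assay is therefore 9.01, expected to lie between 8.7 and 9.32.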

Compound 4, acid dissociation constant: 9.01
Compound 4: the middle estimate sits on the measured number at the digits printed, and the stated range covers the measured number.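

In this assay, the replacement of hydroxy by acetamido gives a number 0.22 log units lower from compound 3 to compound 4 (within the scatter), and on the core of compound 1 the same replacement gave a number 0.22 log units lower from compound 1 to compound 2 (within the scatter), so the two steps read alike at the printed digits. This shows that, across these two pairs, the change carried from one core to the other with the step unaltered in size, but with both steps inside the scatter it does not establish that the change has any real effect on the read-out, and two pairs cannot show that the agreement holds for other cores. Nothing shown here offers an explanation for the result.

The compounds shown carry only hydroxy or acetamido at this place, which leaves open how an amine or a carboxylic acid there would read in this assay. They also leave open whether a longer chain on the amide carbonyl, or the same replacement on a third core, would give a step of similar size.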